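The source may hold more compounds than are shown below. What is called first, only, known or untested is meant among the compounds shown, and "the series" means these compounds.

Compound 1 `Nc1ncnc2c1c(-c1cnc3[nH]ccc3c1)nn2CC(=O)NO`, compound 2 `Nc1ncnc2c1c(-c1cnc3[nH]ccc3c1)nn2CCCCC(=O)NO` and compound 3 `Nc1nc2cc(-c3nn(CCCCCC(=O)NO)c4ncnc(N)c34)ccc2o1` were measured in a functional assay on CNE-2 cells (Homo sapiens) for inhibition, read by MTT assay, with a stated time of 72 h; on this read-out higher numbers stand for weaker inhibition and lower numbers for stronger inhibition.

In this assay compound 1 gives only a limit, > 150000 nM. Compound 2 likewise gives only a limit, > 150000 nM. For the measured compounds named here, compound 3 is the one compound with a number, 37600 nM. The step that the two limits leave unreadable from compound 1 to compound 2 is made by 3-(hydroxycarbamoyl)propyl in place of hydroxycarbamoyl on a saturated chain carbon bound to an aromatic nitrogen; because both ends sit at the limit of > 150000 nM in this assay, at which 2 of the 3 values shown sit, its size cannot be read. The difference between the core of compound 1 and the core of compound 3 is not broken down here.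

Compound 4 `Nc1nc2cc(-c3nn(CCCCCCCCC(=O)NO)c4ncnc(N)c34)ccc2o1` is not yet measured. It arises from compound 3 by 3-(hydroxycarbamoyl)propyl in place of hydroxycarbamoyl on a saturated chain carbon, five bonds along the chain from an aromatic nitrogen, the same kind of change as from compound 1 to compound 2, though the place differs: bound to an aromatic nitrogen in the earlier pair, five bonds along the chain from an aromatic nitrogen here. Since the earlier step is unreadable, the expectation rests on compound 3 alone and its value 37600 nM, and a step of a 1.5-fold lower number from compound 3 to compound 4 (0.18 log units; within the scatter) is estimated. Compound 4 is expected to give 25000 nM, between 8000 nM and 80000 nM.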

Compound 4, half-maximal inhibitory concentration: 3240 nM
For compound 4 the middle estimate is 7.7-fold (0.89 log units) above the measured one, and the stated range ends above it.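

On the core of compound 3, replacing hydroxycarbamoyl with 3-(hydroxycarbamoyl)propyl, on a saturated chain carbon five bonds along the chain from an aromatic nitrogen, gives a 12-fold lower number from compound 3 to compound 4 (1.06 log units; beyond the scatter), so inhibition in this assay is stronger with the longer chain. For the compounds shown here, the same kind of change on the core of compound 1, made at a different place, cannot be read: the limit of > 150000 nM in this assay, at which 2 of the 4 values shown sit. This pair therefore does not show that the gain carries from one core to the other, and the single readable step shows it only for the core of compound 3.

From the compounds shown here alone, it remains open whether a longer chain than that of compound 4 would lower the number further. Going by these compounds, it is also open how a carboxylic acid or an amine in place of hydroxycarbamoyl would read on this chain.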